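Para substituent on the difluorophenyl ring, weaker stereo series

This account rests on a few compounds, and the source may have more. Where it says the series, first, only, none or still open, it means among the compounds named here.

Among the measured compounds shown here, compound 1 `CC[C@H](NC(C)=O)c1cc(Cl)ccc1C1CCN(C(=O)[C@H]2CN(C(C)(C)C)C[C@@H]2c2ccc(F)cc2F)CC1` stands at the top of the numbers so far: in an assay on CHO cells for displacement of a labelled ligand from Melanocortin receptor 4 (Homo sapiens) (a lower number here means a stronger inhibitor, a higher number a weaker inhibitor), compound 1 gives 640 nM, the highest of the three. Its nearest neighbour is compound 2 `CC[C@H](NC(C)=O)c1cc(Cl)ccc1C1CCN(C(=O)[C@@H]2CN(C(C)(C)C)C[C@H]2c2ccc(F)cc2F)CC1`, which in this assay gives 70 nM, with a 9.1-fold lower number from compound 1 to compound 2 (0.96 log units; beyond the scatter); the two are the same compound in all but configuration (the fact that compounds 1 and 2 differ only in the configuration as drawn). Compound 3 `CC[C@H](NC(C)=O)c1cc(Cl)ccc1C1CCN(C(=O)[C@@H]2CN(C(C)(C)C)C[C@H]2c2ccc(Cl)cc2F)CC1` gives 6.2 nM, and an 11-fold lower number from compound 2 to compound 3 (1.05 log units; beyond the scatter).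

Compound 4 `CC[C@H](NC(C)=O)c1cc(Cl)ccc1C1CCN(C(=O)[C@H]2CN(C(C)(C)C)C[C@@H]2c2ccc(C(F)(F)F)cc2F)CC1` keeps the configuration of compound 1 and changes the ring: trifluoromethyl in place of fluoro on an aromatic carbon. For the measured compounds named here, no measured step carries this exact change. The closest comparison is the chloro for fluoro exchange at the same aromatic carbon in the other stereo series, where the step from compound 2 to compound 3 was large and downward. The step from compound 1 to compound 4 is therefore expected to run in the same direction, downward in this assay, though with less confidence in its size, since trifluoromethyl is a different group from chloro and the series of compound 1 has no second point to show how it responds at that position.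

Compound 4 is estimated at 120 nM, within 30 nM to 500 nM, i.e. a 5.3-fold lower number from compound 1 to compound 4 (0.73 log units; beyond the scatter) is expected.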

Compound 4, half-maximal inhibitory concentration: 9.8 nM
Beside the measured number, compound 4's estimate is 12-fold (1.09 log units) above it, outside the stated range (below it).
By their numbers in this assay, from the lowest: compounds 3 and 4 (each within the scatter of the next); then compound 2; then compound 1.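

The aromatic carbon para to a large group now has a measured response in the configuration of compound 1, where previously only the other configuration had one: in this assay there is a 65-fold lower number from compound 1 to compound 4 (1.81 log units; beyond the scatter), with trifluoromethyl in place of fluoro. That step is larger than the one obtained from configuration alone, a 9.1-fold lower number from compound 1 to compound 2 (0.96 log units; beyond the scatter), so of the two steps from compound 1, the change of ring substituent moves the number further than the change of configuration. Reading the second step as purely a matter of configuration rests on one fact: the fact that compounds 1 and 2 differ only in the configuration as drawn.

The compounds shown leave open how trifluoromethyl reads in the configuration of compound 2 and how chloro reads in the configuration of compound 1, so it cannot yet be said whether the two configurations respond alike to a change at this aromatic carbon. Also open, going by these compounds, is how far the response extends to other groups at this carbon, such as a nitrile, a methoxy group, an amine or a carboxylic acid.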